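The source may report more compounds than this note shows. Statements on the series, on what has been measured and on what is new or still open speak of the compounds shown alone.

Measured in a functional assay on Rec1 cells (Homo sapiens) for inhibition, read by luminescence and CellTiter-Glo, with a stated time of 72 h; on this read-out lower numbers stand for stronger inhibition and higher numbers for weaker inhibition:
- compound 1 `C/C=C/C(=O)Nc1cccc(Cn2nc(-c3ccc(Oc4ccccc4)cc3)cc2C(=O)O)c1`: 26000 nM
- compound 2 `C/C=C/C(=O)Nc1cccc(Cn2nc(-c3ccc(Oc4ccccc4)cc3)cc2CO)c1`: 3400 nM
- compound 3 `C/C=C/C(=O)Nc1cccc(Cn2nc(-c3ccc(Oc4ccccc4)cc3)cc2C(=O)OCC)c1`: 7800 nM

Compound 1 has the highest number of the three, which makes it the weakest inhibitor here. The nearest value lies at a 3.3-fold lower number from compound 1 to compound 3 (0.52 log units; beyond the scatter), and the furthest lies at a 7.6-fold lower number from compound 1 to compound 2 (0.88 log units; beyond the scatter).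

Compound 4 `O=C(CCl)Nc1cccc(Cn2nc(-c3ccc(Oc4ccccc4)cc3)cc2C(=O)O)c1` keeps the carboxy group of compound 1 and changes a different place: chloromethyl in place of prop-1-en-1-yl on a carbonyl carbon. In words, this is chloromethyl in place of prop-1-en-1-yl on a carbonyl carbon.

Going by the values given here, no measured step touches that place. All three, including a 2.3-fold higher number from compound 2 to compound 3 (0.36 log units; beyond the scatter), alter the group that is carboxy in compound 1. They therefore show only how far a single change has moved the number in this small set, and each of those moves was modest. Compound 1 sits at the top of the measured numbers at 26000 nM, so a fall seems somewhat likelier than a rise, though the data cannot settle the direction. The expected move is similarly modest, at a 2.0-fold lower number from compound 1 to compound 4 (0.30 log units; within the scatter), and this estimate is uncertain. For compound 4 the estimated value is 13000 nM, expected to lie between 3500 nM and 45000 nM.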

Compound 4, half-maximal inhibitory concentration: 7100 nM
Beside the measured number, compound 4's estimate is 1.8-fold (0.26 log units) above it, and the stated range covers the measured number.
By their numbers in this assay, from the lowest: compound 2; then compounds 4 and 3 (each within the scatter of the next); then compound 1.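

The earlier steps shown here all altered the group that is carboxy in compound 1, whereas this step leaves that group in place and shows that the number also responds to the group on the carbonyl carbon: chloromethyl in place of prop-1-en-1-yl gives a 3.7-fold lower number from compound 1 to compound 4 (0.56 log units; beyond the scatter) in this assay. This second place in the molecule therefore matters as well, and the size of the move is modest, like those seen at the first place. Nothing given here accounts for the drop in the number, so it cannot be tied to any particular feature of either group.

As far as these compounds go, it remains open whether chloromethyl would lower the number in the same way when paired with hydroxymethyl or ethoxycarbonyl rather than carboxy. Also open, from the compounds shown here alone, is how other groups on this carbonyl carbon, such as a plain methyl, an ethenyl or a longer carbon chain, would compare.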